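The source may hold more compounds than are shown below. What is called first, only, known or untested is meant among the compounds shown, and "the series" means these compounds.

Measured so far:
Compound 1 `COc1ccc2c(=O)c(/C=C/C(=O)Nc3ccccc3)coc2c1`: 14000 nM
Compound 2 `COc1ccc(NC(=O)/C=C/c2coc3cc(OC)ccc3c2=O)cc1`: in a functional assay (QGY7701 cells, Homo sapiens) for inhibition, read by MTT assay, with a stated time of 48 h (a higher number here means a weaker inhibitor, a lower number a stronger inhibitor), compound 2 gives only a limit, > 100000 nM

Compound 2 thus stands at the limit of > 100000 nM in this assay, at which 1 of the 2 values shown sits, the weaker of the two measured compounds. For the measured compounds named here, the one measured step, an at least 7.1-fold higher number from compound 1 to compound 2 (0.85 log units; beyond the scatter), came with methoxy in place of hydrogen on an aromatic carbon. Compound 3 `COc1ccc2c(=O)c(/C=C/C(=O)NCc3ccc(C)cc3)coc2c1` differs from compound 2 by 4-methylbenzyl in place of 4-methoxyphenyl on an amide-type nitrogen. Going by the values given here, this change removes the methoxy that arrived in an at least 7.1-fold higher number from compound 1 to compound 2 (0.85 log units; beyond the scatter), so a return toward the level of compound 1 is expected, although no measured step covers the benzyl part. Compound 3 is therefore estimated at 20000 nM, ranging from 5000 nM to 100000 nM. That estimate means a step of an at least 5.0-fold lower number from compound 2 to compound 3 (0.69 log units; beyond the scatter).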

Compound 3, half-maximal inhibitory concentration: 10200 nM
Beside the measured number, compound 3's estimate is 2.0-fold (0.29 log units) above it; measured number inside the range.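

On the amide-type nitrogen, 4-methylbenzyl in place of 4-methoxyphenyl gives an at least 9.8-fold lower number from compound 2 to compound 3 (0.99 log units; beyond the scatter) and so shows that this position can carry an activity level well past that of compound 2. The figure for compound 2 is a limit and not a number: the limit of > 100000 nM in this assay, at which 1 of the 3 values shown sits. Against phenyl, 4-methylbenzyl gives a 1.4-fold lower number from compound 1 to compound 3 (0.14 log units; within the scatter) and so leaves compound 1 and compound 3 level, with only compound 2 apart among the three.

Which part of 4-methylbenzyl matters remains open, and so does what 4-methoxybenzyl, or an amine on that aromatic ring, would give.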